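The compounds below may be only part of what the source reports. "The series", "measured", "known", "first", "only" and "open" are said of these compounds alone.

Compound 1 `COc1ccc(/C=C/C(=O)c2ccc(OC)c3c2OC(C)(C)C=C3)c(F)c1` gives 6570 nM in a functional assay on SW-620 cells (Homo sapiens) for antiproliferative activity, read by MTT assay, with a stated time of 24 h; a higher number here means a weaker inhibitor, a lower number a stronger inhibitor.
Compound 2 `CCN(CC)c1ccc(/C=C/C(=O)c2ccc(OC)c3c2OC(C)(C)C=C3)cc1` gives 670 nM in this assay.
Compound 3 `COc1ccc(C(=O)/C=C/c2ccccc2)c2c1C=CC(C)(C)O2` gives > 10000 nM in this assay; this is a limit of the assay, not a number.

Compound 3 therefore stands at the weak end of what has been measured, as the one of the three for which only a limit is known (the limit of > 10000 nM in this assay, at which 1 of the 3 values shown sits). Going from it to compound 4 `COc1ccc(C(=O)/C=C/c2cccs2)c2c1C=CC(C)(C)O2` means (thiophen-2-yl in place of phenyl on a double-bonded chain carbon bound to a double-bonded chain carbon). The two steps that have been measured both end at compound 3: an at least 1.5-fold higher number from compound 1 to compound 3 (0.18 log units; that floor lies within the scatter) and an at least 14-fold higher number from compound 2 to compound 3 (1.17 log units; beyond the scatter). Both concern a group on the ring that sits on the chain, not the exchange of that ring for another, so neither of them speaks directly to the change toward compound 4. Nothing in the shown values points to a step in either direction beyond the scatter, and the step from compound 3 to compound 4 is expected to be a step that the limit leaves unreadable from compound 3 to compound 4. Compound 4 is therefore estimated at 12000 nM, within a range from 3000 nM to 40000 nM, with a fair chance that only a limit is reported again.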

Compound 4, half-maximal inhibitory concentration: > 10000 nM
Compound 4: no number, only a limit (the forecaster's own chance of this, stated with the estimate: 60%); the middle value lies beyond the limit too.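

Compound 4 is the first compound shown in which the ring on the chain is itself exchanged, thiophen-2-yl in place of phenyl, and in this assay compound 4 is again reported only as a limit of the assay: the limit of > 10000 nM in this assay, at which 2 of the 4 values shown sit. With a limit on both sides, the step for this exchange cannot be read, so thiophen-2-yl may match phenyl here or differ from it anywhere past the limit. Within the data shown here, the one step that can be read (an at least 1.5-fold higher number from compound 1 to compound 4 (0.18 log units; that floor lies within the scatter)) gives only a floor, so it does not separate the two compounds.

Still open, from the compounds shown here alone, is whether diethylamino on an aromatic carbon of a thiophen-2-yl ring would bring a number back, as it does on the phenyl ring (compound 2 gives 670 nM). Also open, going by these compounds, is what a furan-2-yl or pyridine ring on the chain, or a morpholine amine on such a ring, would give.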